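An Isopropyl Group on the Pendant Ring of Compound 1

A few compounds are considered here, and "the series" means these few. Any claim that something is new, unique, unknown or untested is made for them only; others in the source may bear on it.

Compound 1 `O=C1/C(=C/c2ccccc2)Cc2cc(O)ccc21` gives the highest number of the three in an assay on isolated protein for inhibition of Amine oxidase [flavin-containing] A (Homo sapiens), read by fluorescence and spectrophotometry, with a stated time of 20 min (on this read-out higher numbers stand for weaker inhibition and lower numbers for stronger inhibition), at 1940 nM. Compound 2 `O=C1/C(=C/c2cccc(F)c2)Cc2cc(O)ccc21` gives 458 nM in this assay, and compound 3 `N#Cc1cccc(/C=C2\Cc3cc(O)ccc3C2=O)c1` gives 444 nM. The change from compound 1 to compound 4 `CC(C)c1ccc(/C=C2\Cc3cc(O)ccc3C2=O)cc1` is isopropyl in place of hydrogen on an aromatic carbon. The measured steps that bear on it both add a group to the same pendant ring: a 4.2-fold lower number from compound 1 to compound 2 (0.63 log units; beyond the scatter) and a 4.4-fold lower number from compound 1 to compound 3 (0.64 log units; beyond the scatter), each a modest gain. The entering isopropyl carries no hydrogen-bond acceptor and stands para to a large group, at a different place from those two groups, so any gain is expected to be smaller: a 2.2-fold lower number from compound 1 to compound 4 (0.33 log units; beyond the scatter). Compound 4 is therefore expected near 900 nM, within 300 nM to 3000 nM.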

Compound 4, half-maximal inhibitory concentration: 961 nM
The estimate for compound 4 lay 1.1-fold (0.03 log units) below the measured number; the range from low to high includes it.
By their numbers in this assay, from the lowest: compounds 3 and 2 (each within the scatter of the next); then compound 4; then compound 1.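

On the six-membered aromatic ring of carbon only, isopropyl in place of hydrogen, para to a large group, still gives a 2.0-fold lower number from compound 1 to compound 4 (0.31 log units; beyond the scatter) in this assay. This shows that a lower number at this ring does not depend on an entering group with a hydrogen-bond acceptor, since isopropyl has 0 hydrogen-bond acceptors. The compounds shown leave open whether an amine or a carboxylic acid at this same place would lower the number further, and what isopropyl would do at the place held by fluoro in compound 2. No measurement shown accounts for the step.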